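A few compounds are considered here, and "the series" means these few. Any claim that something is new, unique, unknown or untested is made for them only; others in the source may bear on it.

Measured compounds:
compound 1 `COc1ccc(-c2c(S(=O)(=O)c3cccc(F)c3)cnc3cc(F)ccc23)cc1` – 1.89 mL/min
compound 2 `COc1ccc(-c2c(S(=O)(=O)c3ccc(F)cc3)cnc3cc(F)ccc23)cc1` – 1.77 mL/min
compound 3 `COc1ccc(-c2c(S(=O)(=O)c3ccc(F)cc3)cnc3c(F)cccc23)cc1` – 2.41 mL/min

In an ADME assay on microsomes from liver (Homo sapiens) for metabolic stability, tested at 2.5 uM (a lower number here means slower removal, a higher number faster removal of the compound), compound 2 gives 1.77 mL/min, and compound 1 gives 1.89 mL/min. The change 3-fluorophenyl in place of 4-fluorophenyl on a sulfonyl sulfur made a step of a 1.1-fold higher number from compound 2 to compound 1 (0.03 log units; within the scatter). Compound 3 gives 2.41 mL/min; the difference between the core of compound 3 and the core of compound 2 is not broken down here, and the two values are within the scatter of each other.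

Compound 4 `COc1ccc(-c2c(S(=O)(=O)c3cccc(F)c3)cnc3c(F)cccc23)cc1` has not yet been measured in this assay. Among the measured compounds shown here, it differs from compound 3 by 3-fluorophenyl in place of 4-fluorophenyl on a sulfonyl sulfur, the same change as the one from compound 2 to compound 1. Because that step was a 1.1-fold higher number from compound 2 to compound 1 (0.03 log units; within the scatter), the expected step here is a 1.1-fold higher number from compound 3 to compound 4 (0.03 log units; within the scatter). Compound 4 is therefore estimated at 2.6 mL/min, with a range from 1.6 mL/min to 4.2 mL/min.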

Compound 4, intrinsic clearance in a liver preparation (reported as CLH), per the amount of preparation that the assay uses: 2.48 mL/min
Beside the measured number, compound 4's estimate is 1.0-fold (0.02 log units) above it; measured number inside the range.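

In this assay, 3-fluorophenyl in place of 4-fluorophenyl on a sulfonyl sulfur gives a step of a 1.0-fold higher number from compound 3 to compound 4 (0.01 log units; within the scatter), and the two cores show no difference in this change: the same change on two cores in this assay, a 1.1-fold higher number (0.03 log units; within the scatter) from compound 2 to compound 1 and a 1.0-fold higher number (0.01 log units; within the scatter) from compound 3 to compound 4, 1.0-fold (0.02 log units) apart, within the scatter of two such steps. On these two cores, then, the swap carried over as a step inside the scatter each time, so the agreement is between two steps that are both too small to read as an effect. It does not show that a step of real size would carry over in the same way, and two cores cannot speak for the whole series.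

The compounds shown leave open what an amine or a nitrile in place of the fluorine on that phenyl would do in this assay. Also open, going by these compounds, is how a longer ether chain in place of the methoxy group would read.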